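Replacing Phenyl by tert-Butyl on Compound 3

The source may hold more compounds than are shown below. What is called first, only, known or untested is meant among the compounds shown, and "the series" means these compounds.

Within the data shown here, in a physicochemical assay for solubility, in phosphate buffer, at pH 7.4 (on this read-out higher numbers stand for higher solubility and lower numbers for lower solubility), compound 3 `O=C1/C(=C/c2cccc(C(F)(F)F)c2)CC(c2ccccc2)C/C1=C\c1cccc(C(F)(F)F)c1` gives 1100 nM, the only number among the three measured compounds. Compound 1 `N#CC1(c2ccccc2)C/C(=C\c2ccccc2)C(=O)/C(=C/c2ccccc2)C1` reaches only the assay limit of < 1000 nM. Compound 2 `O=C1/C(=C/c2cccc(C(F)(F)F)c2)CCC/C1=C\c1cccc(C(F)(F)F)c1` likewise sits at the limit of < 1000 nM. Among the measured compounds shown here, the step of an at least 1.1-fold higher number from compound 2 to compound 3 (0.04 log units; that floor lies within the scatter) is thus the sole measured comparison, and it stays within the scatter; the two other values sit at the limit of < 1000 nM in this assay, at which 2 of the 3 values shown sit. Compound 4 `CC(C)(C)C1C/C(=C\c2cccc(C(F)(F)F)c2)C(=O)/C(=C/c2cccc(C(F)(F)F)c2)C1` differs from compound 3 by tert-butyl in place of phenyl on a saturated ring carbon. For the measured compounds named here, no measured step exchanges one carbon group for another at this position, so no shift beyond the scatter is expected, with a fair chance that compound 4 again reports only a limit. The expected step of a 1.1-fold lower number from compound 3 to compound 4 (0.04 log units; within the scatter) is accordingly small. Compound 4 is estimated at 1000 nM, ranging from 400 nM to 2500 nM.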

Compound 4, solubility: < 1000 nM
Compound 4: no number, only a limit; the forecaster's own chance of this, stated with the estimate: 50%; the middle value lies on the limit itself.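

Putting tert-butyl in place of phenyl on the saturated ring carbon gives an at least 1.1-fold lower number from compound 3 to compound 4 (0.04 log units; that floor lies within the scatter), so a second carbon group at this position yields no step shown to lie beyond the scatter in this assay. Compound 3 remains the only compound with a number, and the step from compound 2 to compound 4 cannot be read, because both ends are limits: the limit of < 1000 nM in this assay, at which 3 of the 4 values shown sit.

Still open, from the compounds shown here alone, is how far the compounds at the limit lie from it. Also open, going by these compounds, is whether an amine or a carboxylic acid on this ring carbon would give a clearly readable number.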